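The compounds below may be only part of what the source reports. "The series", "measured", "known", "first", "only" and "open" are said of these compounds alone.

Measured compounds:
compound 1, `CCOC(=O)CCCCCOc1cccc(CN(C(=O)c2ccc(-c3cccc(OCC(C)C)c3)cc2)C(C)C)c1`: > 26000 nM
compound 2, `CCOC(=O)CCCCCOc1cccc(CN(C(=O)c2ccc(-c3ccco3)cc2)C(C)C)c1`: > 26000 nM

The two measured compounds share one core and differ only in the aryl group attached to the benzamide ring. In an ADME assay on HEK293 cells (Homo sapiens) for cytotoxicity, read by CellTiter-Glo and resazurin assay, with a stated time of 72 h (a higher number here means that more compound is needed for the effect, a lower number that less compound is needed), compound 1 gives no number but a limit of the assay, > 26000 nM. In this assay compound 2 likewise gives only a limit, > 26000 nM. The step that the two limits leave unreadable from compound 1 to compound 2 therefore cannot be read, and the whole of what the measured pair shows is the limit of > 26000 nM in this assay, at which 2 of the 2 values shown sit.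

Compound 3, `CCOC(=O)CCCCCOc1cccc(CN(C(=O)c2ccc(-c3ccc4cc[nH]c4c3)cc2)C(C)C)c1`, has not yet been measured in this assay. It differs from compound 2 by 1H-indol-6-yl in place of furan-2-yl on an aromatic carbon. Among the compounds with values here, the one measured step at this position, from compound 1 to compound 2, is the only evidence that bears on the change, and since both of its ends are limits it gives no size and no direction. On that basis no step beyond the scatter can be predicted, and compound 3 is expected to sit at or beyond the same limit. Compound 3 is therefore estimated at about 30000 nM in this assay, within a range from 12000 nM to 90000 nM. The expected step from compound 2 to compound 3 is thus a step that the limit leaves unreadable from compound 2 to compound 3.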

Compound 3, half-maximal effective concentration: > 26000 nM
Compound 3: no number, only a limit; the forecaster's own chance of this, stated with the estimate: 75%; the middle value does not contradict the limit.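

In this assay compound 3 gives no number but only a limit of the assay, > 26000 nM. The steps from compound 1 and from compound 2 to compound 3 therefore cannot be read. The compounds shown leave open whether any difference exists among compound 1, compound 2 and compound 3, since all they show is a single limit: the limit of > 26000 nM in this assay, at which 3 of the 3 values shown sit.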